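Opening a dithiolane ring on a catechol-bearing pyrazole

The source may report more compounds than this note shows. Statements on the series, on what has been measured and on what is new or still open speak of the compounds shown alone.

The measured compounds:
- compound 1 `COc1ccc(-c2noc(CCCCC3CCSS3)n2)cc1OC`: in a functional assay on HT-22 cells (Mus musculus), with a stated time of 24 h (on this read-out lower numbers stand for an effect already at smaller amounts and higher numbers for an effect only at larger amounts of compound), compound 1 gives > 10000 nM, which is a limit of the assay and not a number.
- compound 2 `COc1ccc(-c2noc(CCCCC(S)CCS)n2)cc1OC`: in this assay compound 2 gives > 10000 nM, again a limit and not a number.
- compound 3 `Oc1ccc(-c2cc(CCCCCC3CCSS3)n[nH]2)cc1O`: in this assay compound 3 gives 6230 nM.

Compounds 1 and 2 share one core and differ in a single place: a group of 5 heavy atoms (3 carbon, 2 sulfur; no ring) in place of a group of 5 heavy atoms (3 carbon, 2 sulfur; one five-membered non-aromatic ring with 2 hetero atoms), on a saturated chain carbon, four bonds along the chain from an aromatic carbon. The step that the two limits leave unreadable from compound 1 to compound 2 cannot be read, as both values sit at the limit of > 10000 nM in this assay, at which 2 of the 3 values shown sit. Compound 3 carries a different core, and how the two cores differ is not broken down here. Among the three measured compounds, compound 3 is the only one with an actual number.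

Compound 4 `Oc1ccc(-c2cc(CCCCCC(S)CCS)n[nH]2)cc1O` has not yet been measured. It differs from compound 3 by a group of 5 heavy atoms (3 carbon, 2 sulfur; no ring) in place of a group of 5 heavy atoms (3 carbon, 2 sulfur; one five-membered non-aromatic ring with 2 hetero atoms), on a saturated chain carbon, five bonds along the chain from an aromatic carbon. Among the measured compounds shown here, this is the same kind of change as the one from compound 1 to compound 2, but not the same change: in compound 1 the group sits four bonds along the chain from an aromatic carbon, in compound 3 five bonds along the chain from an aromatic carbon.

For the measured compounds named here, the expectation for compound 4 rests on compound 3, whose value is 6230 nM, and on the one measured step of this change, a step that the two limits leave unreadable from compound 1 to compound 2, which has no readable size. For compound 4 a step of a 1.0-fold lower number from compound 3 to compound 4 (0.02 log units; within the scatter) in this assay is expected, close to no change. Compound 4 is estimated at 6000 nM in this assay, with a range from 2000 nM to 20000 nM, and a fair chance that only a limit is reported.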

Compound 4, half-maximal effective concentration: > 10000 nM
Compound 4 was reported as a limit; the forecaster's own chance of this, stated with the estimate: 40%; middle value at least 1.6-fold (0.22 log units) from the limit.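

Replacing the ring with 1,3-disulfanylpropyl on the core of compound 3 gives an at least 1.6-fold higher number from compound 3 to compound 4 (0.20 log units; that floor lies within the scatter) in this assay; this is only a floor, so the real step could be much larger or could stay within the usual scatter of repeated measurements. Among the compounds shown here, the result shows that the open form has no readable number on either core, and that the one number in the pair belongs to the ring-bearing compound 3. It does not show that the change acts alike on both cores, which also differ in where the group sits (four bonds along the chain from an aromatic carbon in one, five bonds in the other), and the step from compound 1 to compound 2 cannot be read, so there is no size to compare, because most of the values are capped: the limit of > 10000 nM in this assay, at which 3 of the 4 values shown sit.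

For the compounds shown here, with compound 3 as the only compound carrying a number, what in its structure accounts for that number remains open. The core of compound 3 with a carboxylic acid or an amine in place of the ring, or with a longer chain, would be needed to tell whether the end of the chain matters at all in this assay.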